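The compounds below may be only part of what the source reports. "The series", "measured", "known", "first", "only" and "open" are said of these compounds alone.

Compound 1 `CN(CCC#N)C[C@H]1CN(c2ccc(-n3cc(-c4ccccn4)cn3)c(F)c2)C(=O)O1` gives > 400 ug/mL in an ADME assay on L02 cells (Homo sapiens) for cytotoxicity, read by MTT assay, with a stated time of 48 h (a higher number here means a weaker inhibitor, a lower number a stronger inhibitor), a limit of the assay rather than a number. Compound 2 `CN1CCN(C[C@H]2CN(c3ccc(-n4cc(-c5ccccn5)cn4)c(F)c3)C(=O)O2)CC1` gives 70 ug/mL. Compound 3 `COC(=O)NC[C@H]1CN(c2ccc(-n3cc(-c4ccccn4)cn3)c(F)c2)C(=O)O1` gives 71 ug/mL.

Compound 1 thus stands at the limit (the limit of > 400 ug/mL in this assay, at which 1 of the 3 values shown sits), with no number of its own. Compound 4 `CCNC(=O)NC[C@H]1CN(c2ccc(-n3cc(-c4ccccn4)cn3)c(F)c2)C(=O)O1` carries (ethylcarbamoyl)amino in place of (2-cyanoethyl)(methyl)amino on a saturated chain carbon bound to a saturated ring carbon. Both measured steps away from compound 1 bear on this change: an at least 5.7-fold lower number from compound 1 to compound 2 (0.75 log units; beyond the scatter) and an at least 5.6-fold lower number from compound 1 to compound 3 (0.75 log units; beyond the scatter), and between compounds 2 and 3 the step is a 1.0-fold higher number from compound 2 to compound 3 (0.01 log units; within the scatter). Compound 3 is the nearer comparison, so a lower number than the limit is expected for compound 4, estimated as an at least 4.4-fold lower number from compound 1 to compound 4 (0.64 log units; beyond the scatter). The expected value for compound 4 is 90 ug/mL, within a range from 35 ug/mL to 300 ug/mL.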

Compound 4, half-maximal inhibitory concentration: > 400 ug/mL
Compound 4 was reported as a limit; the forecaster's own chance of this, stated with the estimate: 20%; at least 4.4-fold (0.64 log units) between middle value and limit.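

In this assay, ethylamino in place of methoxy on the carbonyl carbon gives an at least 5.6-fold higher number from compound 3 to compound 4 (0.75 log units; beyond the scatter), so at this position a change on the carbonyl alone separates the two compounds. The (ethylcarbamoyl)amino group likewise gives an at least 5.7-fold higher number from compound 2 to compound 4 (0.75 log units; beyond the scatter), where it replaces 4-methylpiperazin-1-yl. The step from compound 1 to compound 4 cannot be read, since both values are limits: the limit of > 400 ug/mL in this assay, at which 2 of the 4 values shown sit.

The compounds shown leave open whether a plain amino or a methylamino group on the same carbonyl would behave like ethylamino or like methoxy. They also leave open what a longer chain, such as propylamino, would give.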